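Methyl on the Aromatic Ring in a Whole-Animal Series

The source may hold more compounds than are shown below. What is called first, only, known or untested is meant among the compounds shown, and "the series" means these compounds.

Compound 1 `O=C1OCCN1CC#CCn1ccnc1` and compound 2 `Cc1cncn1CC#CCN1CCOC1=O` were both tested in a functional assay on the whole organism for antagonist activity, with Mus musculus as the target; on this read-out lower numbers stand for an effect already at smaller amounts and higher numbers for an effect only at larger amounts of compound. For compound 1 this assay returns only a limit, > 100 mg/kg. Compound 2 in this assay gives 37 mg/kg. The two differ by methyl in place of hydrogen on an aromatic carbon, and this change brought an at least 2.7-fold lower number from compound 1 to compound 2 (0.43 log units; beyond the scatter). Compound 3 `CN1CCN(CC#CCn2ccnc2)C1=O` is built on another core; how the core of compound 3 differs from that of compound 1 is not broken down here. For compound 3 this assay again returns only a limit, > 100 mg/kg. Compound 4 `Cc1cncn1CC#CCN1CCN(C)C1=O` is not yet measured; it differs from compound 3 by methyl in place of hydrogen on an aromatic carbon, the same change as between compound 1 and compound 2, at a place described in the same words. Across the set, the measurements are dominated by the limit of > 100 mg/kg in this assay, at which 2 of the 3 values shown sit, so the size of the first step is itself uncertain. Compound 4 is expected to show an estimated at least 1.6-fold lower number from compound 3 to compound 4 (0.22 log units; that floor lies within the scatter) because an at least 2.7-fold lower number from compound 1 to compound 2 (0.43 log units; beyond the scatter) followed the same change. Compound 4 is therefore estimated at 60 mg/kg in this assay, with an expected range from 25 mg/kg to 150 mg/kg, and a real chance that only a limit is returned.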

Compound 4, dose for half-maximal effect: 14 mg/kg
The estimate for compound 4 lay 4.3-fold (0.63 log units) above the measured number; measured number outside the range, below it.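

In this assay methyl in place of hydrogen on an aromatic carbon brought an at least 7.1-fold lower number from compound 3 to compound 4 (0.85 log units; beyond the scatter) on the second core, so the number fell on both cores shown and the direction of the change carried over from one to the other: the same change on two cores in this assay, an at least 2.7-fold lower number (0.43 log units; beyond the scatter) from compound 1 to compound 2 and an at least 7.1-fold lower number (0.85 log units; beyond the scatter) from compound 3 to compound 4; the limit leaves it open whether they differ. This does not give the true size of either step, since compound 1 and compound 3 are each known only through a limit of the assay: the limit of > 100 mg/kg in this assay, at which 2 of the 4 values shown sit. Two cores are also a narrow base, and nothing here shows that the change would carry to any further core in the series.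

The compounds shown leave open whether ethyl or chlorine in the same place on the aromatic ring would act as methyl does. They also leave open how a longer chain in place of the present linker, or an amine in place of the ring carbonyl group, would read in this assay.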